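Adding an ethyl group to a growth inhibitor

The source may report more compounds than this note shows. Statements on the series, on what has been measured and on what is new or still open speak of the compounds shown alone.

compound 1 `S=C(N/N=C/c1cccs1)Nc1ccccc1` gives 16700 nM
compound 2 `S=C(N/N=C/c1cccs1)Nc1cccc2ccccc12` gives 1800 nM

In a functional assay on K562 cells (Homo sapiens) for inhibition, read by sulforhodamine B assay, with a stated time of 48 h (on this read-out lower numbers stand for stronger inhibition of growth and higher numbers for weaker inhibition of growth), compound 1 stands at 16700 nM as the highest of the two numbers, so it is the weaker inhibitor. Compound 3 `CCc1ccc(NC(=S)N/N=C/c2cccs2)cc1` changes one place on the core of compound 1 by ethyl in place of hydrogen on an aromatic carbon as ethyl in place of hydrogen on an aromatic carbon. Going by the values given here, no measured pair shows this change. The aromatic group also differs in compound 2, which gives 1800 nM as a lower number, so a modest drop is expected. The estimated change is a 2.4-fold lower number from compound 1 to compound 3 (0.38 log units; beyond the scatter) and would lie slightly beyond the scatter. Compound 3 is estimated at 7000 nM with an expected range from 2500 nM to 20000 nM in this measurement.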

Compound 3, concentration for 50% growth inhibition: 1600 nM
Compound 3: the middle estimate sits 4.4-fold (0.64 log units) above what was measured; the measured number lies below the stated range.
By their numbers in this assay, from the lowest: compounds 3 and 2 (each within the scatter of the next); then compound 1.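

In this assay ethyl in place of hydrogen on an aromatic carbon, para to a large group, gives a 10-fold lower number from compound 1 to compound 3 (1.02 log units; beyond the scatter) and so counts as a large step. Going by these compounds alone, this is the first single change read at this position, and it shows that adding only 2 heavy atoms here can strongly alter growth inhibition. Nothing available explains this gain. On these data alone, whether a longer chain such as butyl would go further remains open, and so does the effect of an amine at this same place.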